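The source may hold more compounds than are shown below. What is called first, only, known or untested is meant among the compounds shown, and "the series" means these compounds.

The measured compounds:
- compound 1, `O=C1C(Nc2ccccc2F)=CC(=O)c2c1nc1n2[C@H]2OC[C@@H](O)[C@H]2OC1`
- compound 2, `O=C1C=C(Nc2ccccc2F)C(=O)c2c1nc1n2[C@H]2OC[C@@H](O)[C@H]2OC1`
- compound 3, `Cc1ccc(NC2=CC(=O)c3c(nc4n3[C@H]3OC[C@@H](O)[C@H]3OC4)C2=O)cc1C`

In a functional assay on MCF7 cells (Homo sapiens) for inhibition, read by sulforhodamine B assay (a higher number here means a weaker inhibitor, a lower number a stronger inhibitor), compound 2 gives 3640 nM and compound 3 gives 4950 nM. For compound 1 this assay gives only a limit, > 4000 nM. Among the two actual numbers, compound 2 has the lower one, but its nearest neighbour, compound 3, sits within the usual scatter of it, so the two cannot be ranked.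

Going by the values given here, the only step between measured compounds runs from the limit of compound 1 to compound 3: a step that the limit leaves unreadable from compound 1 to compound 3 (the limit of > 4000 nM in this assay, at which 1 of the 3 values shown sits).

The new compound is compound 4, `CCOc1ccccc1NC1=CC(=O)c2nc3n(c2C1=O)[C@H]1OC[C@@H](O)[C@H]1OC3`. It differs from compound 2 in one place: ethoxy in place of fluoro on an aromatic carbon.

Among the compounds with values here, no measured step covers this change. Within the data shown here, the one step that exists swaps the aryl group on the amine nitrogen from a different starting point and is unreadable, so it gives no size to carry over. With compound 2 and compound 3 both close together, the shared core appears to tolerate different aryl groups without a large shift. The change expected here is a 1.0-fold lower number from compound 2 to compound 4 (0.02 log units; within the scatter), within the scatter. Compound 4 is therefore estimated at about 3500 nM, between 1500 nM and 8000 nM.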

Compound 4, half-maximal inhibitory concentration: > 4000 nM
Compound 4 gave a limit, no number; the forecaster's own chance of this, stated with the estimate: 30%; middle value at least 1.1-fold (0.05 log units) from the limit.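

In this assay compound 4 gives only a limit (> 4000 nM). Going from 2-fluorophenyl to 2-ethoxyphenyl reads as an at least 1.0-fold higher number from compound 2 to compound 4 (0.04 log units; that floor lies within the scatter) and so reveals something the earlier compounds could not: on this aromatic carbon, ortho to a large group, the larger ethoxy group with its added hydrogen-bond acceptor brings no readable gain in strength, while the true size of the change remains unknown. A second compound now gives no exact number, so the comparisons this assay can support are narrowing: the limit of > 4000 nM in this assay, at which 2 of the 4 values shown sit.

As far as these compounds go, what this position would do with a small group such as methoxy, with a longer chain such as butoxy, or with an amine or a carboxylic acid remains open. Also open, from the compounds shown here alone, is whether ethoxy would behave the same way on another carbon of the ring, and a real number for compound 4 would be needed before the size of this change could be stated.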